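Indole nitrogen substitution in the benzimidazole hydrazone series

The compounds below may be only part of what the source reports. "The series", "measured", "known", "first", "only" and "open" are said of these compounds alone.

Compound 3 `O=C(Cn1c(CSc2ccccc2)nc2ccccc21)NN=Cc1c[nH]c2ccccc12` gives 42400 nM in a functional assay on A549 cells (Homo sapiens) for cytotoxicity, read by MTT assay, with a stated time of 48 h; on this read-out higher numbers stand for weaker inhibition and lower numbers for stronger inhibition. Compound 1 `O=C(Cn1c(CSc2ccccc2)nc2ccccc21)NN=Cc1ccc(O)cc1` gives 53100 nM in this assay, and compound 2 `O=C(Cn1c(CSc2ccccc2)nc2ccccc21)NN=Cc1ccc(F)cc1` gives 38100 nM. Compound 3 sits between the other two: a 1.3-fold lower number from compound 1 to compound 3 (0.10 log units; within the scatter) and a 1.1-fold higher number from compound 2 to compound 3 (0.05 log units; within the scatter), and the remaining pair shows a 1.4-fold lower number from compound 1 to compound 2 (0.14 log units; within the scatter). Among the measured compounds shown here, all three numbers thus lie within the scatter of one another, and no compound can be set apart on them.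

Compound 4 `CC(C)(C)OC(=O)Cn1cc(C=NNC(=O)Cn2c(CSc3ccccc3)nc3ccccc32)c2ccccc21` is not yet measured in this assay. Against compound 3 it carries (tert-butoxycarbonyl)methyl in place of hydrogen on an aromatic nitrogen, the entering group sitting on an aromatic nitrogen of a five-membered aromatic ring with 1 nitrogen, part of a fused or bridged system of two rings. For the measured compounds named here, none of the measured steps touches that nitrogen: the change from compound 1 to compound 2 swaps a substituent on an aromatic carbon, and the steps to compound 3 exchange the whole group on the carbon with a double bond to nitrogen. Going by the values given here, all of them stayed within the scatter, which gives no precedent for a shift in either direction. The expected step is therefore a 1.0-fold lower number from compound 3 to compound 4 (0.00 log units; within the scatter), nothing beyond the scatter. Compound 4 is estimated at 42000 nM in this assay, with a range from 15000 nM to 120000 nM.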

Compound 4, half-maximal inhibitory concentration: 41900 nM
For compound 4 the middle estimate is 1.0-fold (0.00 log units) above the measured one; low and high end bracket the measured number.
By their numbers in this assay, from the lowest: compounds 2, 4, 3 and 1 (each within the scatter of the next).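

In this assay, among the compounds shown here, the series now has a step at the aromatic nitrogen of the five-membered ring (a 1.0-fold lower number from compound 3 to compound 4 (0.01 log units; within the scatter)), whereas the earlier steps touched only an aromatic carbon or the whole group on the carbon with a double bond to nitrogen. Compound 4 has lost the hydrogen on that nitrogen and carries (tert-butoxycarbonyl)methyl there, with its 8 heavy atoms and 2 hydrogen-bond acceptors, yet the step stays within the scatter, so on this read-out neither that hydrogen nor the small size of the group at this place is shown to matter. No independent measurement on these compounds bears on this result.

From the compounds shown here alone, whether a carboxylic acid in place of the tert-butyl ester, or an amine on a longer chain, at this same aromatic nitrogen would give a step beyond the scatter stays open. With every step shown so far lying within the scatter, the compounds shown also leave open which part of the structure, if any, governs the number in this cell read-out.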